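This account rests on a few compounds, and the source may have more. Where it says the series, first, only, none or still open, it means among the compounds named here.

In an assay for inhibition of serine/threonine-protein kinase PAK 4 (Homo sapiens), read by FRET and Z'-LYTE, with a stated time of 60 min, tested at 0.5 uM, in the presence of a further agent that is not named here (a higher number here means a stronger effect of the compound at the concentration tested, a lower number a weaker effect), compound 1 `CC(C)COC(=O)N1CCN(C(=O)c2nc(Nc3cc(C4CC4)[nH]n3)c3cc(Cl)ccc3n2)C[C@H]1C` gives 0.8%. Within the data shown here, only one other compound has been measured beside it: compound 2 `C[C@@H]1CN(C(=O)c2nc(Nc3cc(C4CC4)[nH]n3)c3cc(Cl)ccc3n2)CCN1C(=O)OC(C)(C)C`, which gives 0.1%, a result that lies within the usual scatter of the result for compound 1, so the two cannot be told apart on these numbers. Compound 3 `CC(OC(=O)C(C)C)OC(=O)N1CCN(C(=O)c2nc(Nc3cc(C4CC4)[nH]n3)c3cc(Cl)ccc3n2)C[C@H]1C` has not yet been measured. It differs from compound 1 in a single place: 1-((isopropylcarbonyl)oxy)ethyl in place of isobutyl on an oxygen next to a carbonyl group. Among the measured compounds shown here, the one measured step at the same place, a number 0.7 percentage points lower from compound 1 to compound 2 (within the scatter), exchanged the group on that oxygen without moving the read-out beyond the scatter. For the measured compounds named here, that step is the only guide, and the change to compound 3 is larger than the one it covers, so the guidance is weak. Given a number 0.7 percentage points lower from compound 1 to compound 2 (within the scatter) and the low result of compound 1 itself, 0.8%, compound 3 is expected to show a number 0.2 percentage points higher from compound 1 to compound 3 (within the scatter), nothing beyond the scatter. The estimate for compound 3 is 1%, within -8% to 10%.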

Compound 3, a percentage reported as inhibition, at one concentration (the size of the read-out at that concentration, not a potency): 9.4%
For compound 3 the middle estimate is 8.4 percentage points below the measured one, within the range that was stated.
By their numbers in this assay, from the lowest: compounds 2, 1 and 3 (each within the scatter of the next).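

In this assay, the oxygen next to a carbonyl group now carries 1-((isopropylcarbonyl)oxy)ethyl, a larger group than isobutyl, with hydrogen-bond acceptors that isobutyl lacks. Even so, the exchange for isobutyl gives a number 8.6 percentage points higher from compound 1 to compound 3 (within the scatter), and the exchange for tert-butyl gives a number 9.3 percentage points higher from compound 2 to compound 3 (within the scatter), so this much bigger change at this position still does not separate the compounds. Nothing measured alongside these numbers offers an explanation for this result.

The compounds shown leave open whether a different kind of group on this oxygen, such as one carrying an amine or a carboxylic acid, would move the read-out beyond the scatter. Because each compound is reported at a single concentration, they also leave open whether compound 3 and compound 1 would differ at a higher one.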